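The source may hold more compounds than are shown below. What is called first, only, known or untested is meant among the compounds shown, and "the series" means these compounds.

Measured in a functional assay on PC-3 cells (Homo sapiens) for cytotoxicity, read by sulforhodamine B assay, with a stated time of 48 h; a higher number here means a weaker inhibitor, a lower number a stronger inhibitor:
- compound 1 `COc1ccc(C2=NO[C@]3(C2)C(=O)O[C@@H]2[C@H]3CC[C@H](C)[C@]3(O)C=CC(=O)[C@@]23C)cc1`: 35000 nM
- compound 2 `C[C@H]1CC[C@@H]2[C@@H](OC(=O)[C@]23CC(c2ccc(Cl)cc2)=NO3)[C@]2(C)C(=O)C=C[C@@]12O`: 49000 nM
- compound 3 `C[C@H]1CC[C@@H]2[C@@H](OC(=O)[C@]23CC(c2ccc(O)cc2)=NO3)[C@]2(C)C(=O)C=C[C@@]12O`: 20000 nM

In this assay compound 3 gives 20000 nM. The data show a 1.8-fold lower number from compound 1 to compound 3 (0.24 log units; within the scatter), and a 2.5-fold lower number from compound 2 to compound 3 (0.39 log units; beyond the scatter).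

Compound 4 `COc1cc(C2=NO[C@]3(C2)C(=O)O[C@@H]2[C@H]3CC[C@H](C)[C@]3(O)C=CC(=O)[C@@]23C)ccc1O` carries one change: methoxy in place of hydrogen on an aromatic carbon. This is methoxy in place of hydrogen on an aromatic carbon, ortho to a hydroxy group and meta to a large group, turning 4-hydroxyphenyl into 4-hydroxy-3-methoxyphenyl.

Among the measured compounds shown here, no measured step adds a group at this place. The nearest evidence is indirect: a 1.8-fold lower number from compound 1 to compound 3 (0.24 log units; within the scatter) concerns a methyl on the oxygen of the same ring, and a 1.4-fold higher number from compound 1 to compound 2 (0.15 log units; within the scatter) is a swap on that ring. The largest step on this ring so far remains modest: a 2.5-fold lower number from compound 2 to compound 3 (0.39 log units; beyond the scatter). A step beyond the scatter is therefore not expected.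

The estimated step is a 1.3-fold higher number from compound 3 to compound 4 (0.10 log units; within the scatter). Compound 4 is expected at 25000 nM. The estimated range runs from 12000 nM to 50000 nM.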

Compound 4, half-maximal inhibitory concentration: 16000 nM
The estimate for compound 4 lay 1.6-fold (0.19 log units) above the measured number; the measured number falls inside the stated range.
By their numbers in this assay, from the lowest: compounds 4, 3, 1 and 2 (each within the scatter of the next, the first and the last beyond it).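

In this assay, among the compounds shown here, methoxy on an aromatic carbon ortho to a hydroxy group is accepted: turning 4-hydroxyphenyl into 4-hydroxy-3-methoxyphenyl gives a 1.3-fold lower number from compound 3 to compound 4 (0.10 log units; within the scatter), so this is the first added group on the ring, and its step cannot be told from the scatter. For the compounds shown here, compound 3 stood beyond the scatter of only one earlier compound, whereas compound 4 separates from both others, with a 2.2-fold lower number from compound 1 to compound 4 (0.34 log units; beyond the scatter) and a 3.1-fold lower number from compound 2 to compound 4 (0.49 log units; beyond the scatter), though both steps are modest. No supporting measurement accompanies these numbers, so no cause can be assigned.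

Going by these compounds, whether an amine or a carboxylic acid on this aromatic carbon would move the number beyond the scatter stays open. Also open, on these data alone, is what methoxy does here without the hydroxy group.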